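The source may hold more compounds than are shown below. What is called first, only, known or untested is meant among the compounds shown, and "the series" means these compounds.

Measured compounds in an ADME assay (liver) for metabolic stability, with Liver microsome (Homo sapiens) as the target, using microsomes and NADPH, with a stated time of 30 min, tested at 1 uM; a higher number here means faster removal of the compound, a lower number slower removal:
- compound 1, `Nc1ccc(S(=O)(=O)N2CCN(c3ncc(C(O)(C(F)(F)F)C(F)(F)F)cc3Br)CC2)cn1`: compound 1 reaches only the assay limit, < 14 mL.min-1.g-1.
- compound 2, `Cn1cc(-c2cc(C(O)(C(F)(F)F)C(F)(F)F)cnc2N2CCN(S(=O)(=O)c3ccc(N)nc3)CC2)cn1`: compound 2 gives 19 mL.min-1.g-1.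
- compound 3, `NC(=O)c1cccc(-c2cc(C(O)(C(F)(F)F)C(F)(F)F)cnc2N2CCN(S(=O)(=O)c3ccc(N)nc3)CC2)c1`: compound 3 gives 17 mL.min-1.g-1.

Compound 2 and compound 3 are the two numbered values; the pair sits within the scatter, a 1.1-fold lower number from compound 2 to compound 3 (0.05 log units; within the scatter). Against compound 1 only a limit is available, (the limit of < 14 mL.min-1.g-1 in this assay, at which 1 of the 3 values shown sits), so the steps of an at least 1.3-fold higher number from compound 1 to compound 2 (0.13 log units; that floor lies within the scatter) and an at least 1.2-fold higher number from compound 1 to compound 3 (0.08 log units; that floor lies within the scatter) are floors that lie within the scatter.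

Compound 4, `Cc1ccc(-c2cc(C(O)(C(F)(F)F)C(F)(F)F)cnc2N2CCN(S(=O)(=O)c3ccc(N)nc3)CC2)cn1`, is not yet measured in this assay. Its change from compound 2: 6-methylpyridin-3-yl in place of 1-methyl-1H-pyrazol-4-yl on an aromatic carbon.

The step that bears most directly on this change is the swap of aryl groups on the same carbon, a 1.1-fold lower number from compound 2 to compound 3 (0.05 log units; within the scatter), which stayed within the scatter, while both arylations of compound 1 gave only floors within the scatter. The change to compound 4 is therefore expected to move this assay by no step beyond the scatter, no change at the digits printed from compound 2 to compound 4 (within the scatter). Compound 4 is estimated at 19 mL.min-1.g-1, within 10 mL.min-1.g-1 to 38 mL.min-1.g-1.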

Compound 4, intrinsic clearance in microsomes: 43 mL.min-1.g-1
Compound 4: the middle estimate sits 2.3-fold (0.35 log units) below what was measured, outside the stated range (above it).
By their numbers in this assay, from the lowest: compounds 3 and 2 (each within the scatter of the next); then compound 4. At a limit, below all of these: compound 1.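

In this assay, the aromatic carbon ortho to a large group proves sensitive to which aryl group it carries: a 2.3-fold higher number from compound 2 to compound 4 (0.35 log units; beyond the scatter), and a 2.5-fold higher number from compound 3 to compound 4 (0.40 log units; beyond the scatter), whereas the exchange of 1-methyl-1H-pyrazol-4-yl for 3-carbamoylphenyl had stayed within the scatter. An aryl group in place of bromo therefore does not fix the number by itself, and 6-methylpyridin-3-yl is the one group shown that separates from the other two. The step of an at least 3.0-fold higher number from compound 1 to compound 4 (0.48 log units; beyond the scatter) is the first from bromo to clear the scatter, yet it remains a floor, as compound 1 stands at a limit: the limit of < 14 mL.min-1.g-1 in this assay, at which 1 of the 4 values shown sits.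

The compounds shown do not tell whether the rise goes with the methyl group or with the six-membered ring. Unsubstituted pyridin-3-yl, or an amine or methoxy group in place of that methyl, would separate the two.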